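A few compounds are considered here, and "the series" means these few. Any claim that something is new, unique, unknown or untested is made for them only; others in the source may bear on it.

In an assay on isolated protein for inhibition of serine/threonine-protein kinase PAK 1 (Homo sapiens), read by ADP-Glo, with a stated time of 40 min (a lower number here means a stronger inhibitor, a higher number a weaker inhibitor), three compounds built on one shared core have been measured. Compound 1 `O=C(NC1CCN(c2ncnc3[nH]ncc23)CC1)c1ccc(F)cc1` gives 4540 nM, compound 2 `O=C(NC1CCN(c2ncnc3[nH]ncc23)CC1)c1ccc(Br)cc1` gives 16400 nM, and compound 3 `Cc1cccc(C)c1NC(=O)NC1CCN(c2ncnc3[nH]ncc23)CC1` gives 2160 nM. Compound 2 stands highest of the three, as seen in a 3.6-fold higher number from compound 1 to compound 2 (0.56 log units; beyond the scatter) and in a 7.6-fold lower number from compound 2 to compound 3 (0.88 log units; beyond the scatter). Compound 4 `O=C(Nc1ccc(Cl)c(Cl)c1)NC1CCN(c2ncnc3[nH]ncc23)CC1` has not yet been measured; it differs from compound 2 in one place ((3,4-dichlorophenyl)amino in place of 4-bromophenyl on a carbonyl carbon). The measured steps that bear on this change are a 7.6-fold lower number from compound 2 to compound 3 (0.88 log units; beyond the scatter) and a 2.1-fold lower number from compound 1 to compound 3 (0.32 log units; beyond the scatter), both of which put (2,6-dimethylphenyl)amino on the carbonyl carbon in place of a halophenyl and both of which lower the number beyond the scatter. Among the measured compounds shown here, no measured step separates (3,4-dichlorophenyl)amino from (2,6-dimethylphenyl)amino, so the size remains uncertain. Compound 4 is therefore expected to show a lower number than compound 2, with a step estimated as a 5.5-fold lower number from compound 2 to compound 4 (0.74 log units; beyond the scatter). In this assay compound 4 is estimated at 3000 nM, with a range from 900 nM to 10000 nM.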

Compound 4, half-maximal inhibitory concentration: 2290 nM
Estimate against measurement, compound 4: 1.3-fold (0.12 log units) above; low and high end bracket the measured number.
By their numbers in this assay, from the lowest: compounds 3, 4 and 1 (each within the scatter of the next, the first and the last beyond it); then compound 2.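

In this assay, (3,4-dichlorophenyl)amino on the carbonyl carbon gives a 7.2-fold lower number from compound 2 to compound 4 (0.86 log units; beyond the scatter) in place of 4-bromophenyl, so a second substituted phenylamino group, after the 2,6-dimethylphenyl one, also clears the scatter against this bromo amide. Exchanging the ring on the amide-type nitrogen gives a 1.1-fold higher number from compound 3 to compound 4 (0.03 log units; within the scatter) and so separates neither ring, while the fluoro amide is not clearly separated from the new compound either, with a 2.0-fold lower number from compound 1 to compound 4 (0.30 log units; within the scatter) as its step. Nothing on hand accounts for these steps.

The compounds shown leave open whether the added nitrogen matters in itself, as no pair carries the same phenyl group with and without it. They also leave open how an unsubstituted phenyl, a pyridine or a carboxylic acid on the ring would read here.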